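The compounds below may be only part of what the source reports. "The series", "measured", "known", "first", "only" and "open" are said of these compounds alone.

In a functional assay on MCF7 cells (Homo sapiens) for inhibition, read by CCK-8 assay, with a stated time of 48 h (on this read-out lower numbers stand for stronger inhibition and higher numbers for weaker inhibition), three compounds sharing one core differ only in one aromatic group. Compound 1 `COc1cc(-c2ccnc3cc(-c4ccc(Cl)cc4)nn23)cc(OC)c1OC`, with 4-chlorophenyl, gives 2320 nM here. Compound 2 `COc1cc(-c2ccnc3cc(-c4cccc(C#N)c4)nn23)cc(OC)c1OC`, with 3-cyanophenyl, shows > 10000 nM as a limit of the assay, not a number. Among the measured compounds shown here, compound 3 `COc1cc(-c2ccnc3cc(-c4cccc(C)c4)nn23)cc(OC)c1OC`, with 3-methylphenyl, gives 1080 nM as the lowest number so far.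

Compound 4 `COc1ccc(-c2cc3nccc(-c4cc(OC)c(OC)c(OC)c4)n3n2)cc1F` is still unmeasured. It carries 3-fluoro-4-methoxyphenyl in place of 3-methylphenyl on an aromatic carbon of the same core.

For the measured compounds named here, no measured compound carries this new group, so the earlier swaps at this place are the only guide. They include a 2.1-fold lower number from compound 1 to compound 3 (0.33 log units; beyond the scatter) and an at least 4.3-fold higher number from compound 1 to compound 2 (0.63 log units; beyond the scatter), while an at least 9.2-fold lower number from compound 2 to compound 3 (0.96 log units; beyond the scatter) shows how much the choice of group can matter. Since compound 3 holds the lowest number, a move upward seems likelier than a further drop. The expected change is small, a 1.9-fold higher number from compound 3 to compound 4 (0.27 log units; within the scatter), and it may not clear the usual scatter. For compound 4 the estimated value is 2000 nM, with an expected range from 600 nM to 7000 nM in this read-out.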

Compound 4, half-maximal inhibitory concentration: 183 nM
Compound 4: the middle estimate sits 11-fold (1.04 log units) above what was measured; the whole stated range lies above it.
By their numbers in this assay, from the lowest: compound 4; then compound 3; then compound 1. At a limit, above all of these: compound 2.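

In this assay, the earlier groups left unclear whether this position could reach much lower numbers, and the 3-fluoro-4-methoxyphenyl group shows that it can, with a 5.9-fold lower number from compound 3 to compound 4 (0.77 log units; beyond the scatter) and a 13-fold lower number from compound 1 to compound 4 (1.10 log units; beyond the scatter). Here the lowest number goes with a phenyl ring carrying two substituents, whereas the other groups shown each carry one. An even larger gap appears in an at least 54-fold lower number from compound 2 to compound 4 (1.73 log units; beyond the scatter), but that step starts from a limit and not a number: the limit of > 10000 nM in this assay, at which 1 of the 4 values shown sits.

As far as these compounds go, what the fluorine and the methoxy group each contribute stays open, including whether a 3-fluorophenyl or a 4-methoxyphenyl group alone would keep the number this low. Also open, from the compounds shown here alone, is how an amine or a carboxylic acid on that phenyl ring would read out.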